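A few compounds are considered here, and "the series" means these few. Any claim that something is new, unique, unknown or untested is made for them only; others in the source may bear on it.

Measured in a functional assay on MCF7 cells (Homo sapiens) for antiproliferative activity, read by MTT assay, with a stated time of 24 h; on this read-out higher numbers stand for weaker inhibition and lower numbers for stronger inhibition:
Compound 1 `O=C1O/C(=C\Cn2cc(C3=CCCCC3)nn2)C(OCc2ccccc2)=C1OCc1ccccc1` gives > 100000 nM in this assay, a limit of the assay rather than a number.
Compound 2 `O=C1NC(O)(CCn2cc(Cc3ccccc3)nn2)C(OCc2ccccc2)=C1OCc1ccccc1` gives 39200 nM in this assay.
Compound 3 `O=C1NC(O)(CCn2cc(-c3ccccc3)nn2)C(OCc2ccccc2)=C1OCc1ccccc1` gives 20500 nM in this assay.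

Compound 1 stands only at the limit of > 100000 nM in this assay, at which 1 of the 3 values shown sits, with no number of its own. Within the data shown here, the single measured step, a 1.9-fold lower number from compound 2 to compound 3 (0.28 log units; within the scatter), exchanges the group on the triazole within a different core and lies within the scatter. Compound 4 `O=C1O/C(=C\Cn2cc(-c3ccccn3)nn2)C(OCc2ccccc2)=C1OCc1ccccc1` carries the change (pyridin-2-yl in place of cyclohex-1-en-1-yl on an aromatic carbon). Among the measured compounds shown here, no measured step covers this exchange on the core of compound 1, and the one step available points to little movement from such a swap. Compound 4 is therefore expected near the limit of compound 1, with a number no higher from compound 1 to compound 4 (the limit leaves the size open) expected small, an estimate of 100000 nM spanning 30000 nM to 300000 nM, and a limit again being likely.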

Compound 4, half-maximal inhibitory concentration: > 100000 nM
Compound 4 was reported as a limit (the forecaster's own chance of this, stated with the estimate: 55%); the middle value lies on the limit itself.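

Compound 1 and compound 4 are both reported only as limits, so the step between them cannot be read: the limit of > 100000 nM in this assay, at which 2 of the 4 values shown sit.

Going by these compounds, whether pyridin-2-yl and cyclohex-1-en-1-yl differ at all on the core of compound 1 remains open.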